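This account rests on a few compounds, and the source may have more. Where it says the series, first, only, none or still open, it means among the compounds named here.

Values in a functional assay on HL-60 cells (Homo sapiens) for inhibition, read by CCK-8 assay, with a stated time of 48 h, tested at 20 uM; a higher number here means more inhibition of growth at the concentration tested, a lower number less inhibition of growth:
Compound 1 `COc1ccc(Cc2nnc(NC(=O)/C(C#N)=C/c3ccccc3OS(=O)(=O)c3ccc(Cl)cc3)s2)cc1`: 20%
Compound 2 `COc1ccc(S(=O)(=O)Oc2ccccc2/C=C(\C#N)C(=O)Nc2nnc(Cc3ccc(C)cc3)s2)cc1`: 100%

Compound 2 stands highest of the two numbers in this assay, and the gap down to compound 1 lies beyond the usual scatter. Compound 3 `Cc1ccc(Cc2nnc(NC(=O)/C(C#N)=C/c3ccccc3OS(=O)(=O)c3ccc(Cl)cc3)s2)cc1` differs from compound 2 at one place, on an aromatic carbon para to a large group, with chloro in place of methoxy on an aromatic carbon. The group therefore changes from 4-methoxyphenyl to 4-chlorophenyl. Within the data shown here, no measured pair differs in one place only, so the size of this change has no direct precedent. Compound 2, at 100%, is the higher of the two values, so any change beyond the scatter is expected to be downward. The expected change is a number 35 percentage points lower from compound 2 to compound 3 (beyond the scatter), a moderate loss with wide uncertainty. For compound 3 the estimate is 65%, with an expected range of 25% to 100%.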

Compound 3, percent growth inhibition at one concentration: 38%
Compound 3: the middle estimate sits 27 percentage points above what was measured, and the stated range covers the measured number.
By their numbers in this assay, from the lowest: compound 1; then compound 3; then compound 2.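

In this assay, among these compounds, (4-chlorophenyl)sulfonyl in place of (4-methoxyphenyl)sulfonyl gives a number 62 percentage points lower from compound 2 to compound 3 (beyond the scatter) and is the first single-place change at this position, showing that the position is sensitive when the other aromatic ring carries methyl. Compound 3 also provides a single-place reading at that other ring, where methoxy gives way to methyl and the result is a number 18 percentage points higher from compound 1 to compound 3 (beyond the scatter) in this assay with (4-chlorophenyl)sulfonyl held constant, so both sites respond beyond the scatter. No measurement available here accounts for either change.

Going by these compounds, it remains open whether methoxy to chloro keeps this size when the other ring carries methoxy instead of methyl. Also open, on these data alone, is how a fluoro, an amine or a carboxylic acid would read in place of the methoxy on the sulfonyl-bearing ring.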